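From Chloro to Nitro: One Swap, One Open Number

This account rests on a few compounds, and the source may have more. Where it says the series, first, only, none or still open, it means among the compounds named here.

In a functional assay on Bel-7402 cells (Homo sapiens) for antiproliferative activity, read by MTT assay, with a stated time of 72 h (a lower number here means a stronger inhibitor, a higher number a weaker inhibitor), compound 1 `Cc1ccccc1NC(=O)C(Cl)Cl` has no usable result, its entry being "not determined" (no result reported). Compound 2 `O=C(Nc1cccc(Cl)c1)C(Cl)Cl` gives 44500 nM. Going by the values given here, that is the only number available so far, so compound 2 cannot yet be ranked against anything else. The next compound to be tested is compound 3 `O=C(Nc1cccc([N+](=O)[O-])c1)C(Cl)Cl`, which differs from compound 2 by a single swap, nitro in place of chloro on an aromatic carbon. Among the compounds with values here, no measured pair shows what a change at this place does to the result, so any forecast here is cautious. The expected step of a 1.1-fold higher number from compound 2 to compound 3 (0.05 log units; within the scatter) is small, probably no larger than the usual scatter of repeat measurements, and no direction is favoured. For compound 3 the estimated value is 50000 nM, with an expected range from 18000 nM to 130000 nM.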

Compound 3, half-maximal inhibitory concentration: 15700 nM
Beside the measured number, compound 3's estimate is 3.2-fold (0.50 log units) above it, outside the stated range (below it).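

In this assay this place on the aromatic ring proves sensitive to the group it carries: nitro in place of chloro gives a 2.8-fold lower number from compound 2 to compound 3 (0.45 log units; beyond the scatter) and that modest step lies beyond the usual scatter. Going by these compounds alone, until this pair no measured step existed at all, so this is the first sign that a change here can shift the result, although a single pair cannot set a trend. Nothing available explains why the nitro compound is the stronger of the two.

As far as these compounds go, whether an amine, a carboxylic acid or a methoxy group at the same place would lower the number further or raise it remains open. Within the data shown here, compound 1 has no usable result, so no step involving it can be read.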